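The compounds below may be only part of what the source reports. "The series", "measured", "known", "first", "only" and "open" are said of these compounds alone.

Measured compounds in a functional assay on MCF7 cells (Homo sapiens) for antiproliferative activity, read by CCK-8 assay, with a stated time of 48 h; a higher number here means a weaker inhibitor, a lower number a stronger inhibitor:

compound 1, `Cc1[nH]c2ccccc2c1C1=C(Br)C(=O)C(c2c(-c3ccccc3)[nH]c3ccccc23)=C(Br)C1=O`, 3.02 ug/mL
compound 2, `Cc1ccc(-c2[nH]c3ccccc3c2C2=C(Br)C(=O)C(c3c(C)[nH]c4ccccc34)=C(Br)C2=O)cc1`, 3.25 ug/mL
compound 3, `Cc1[nH]c2ccccc2c1C1=C(Br)C(=O)C(Br)=C(c2c(C)[nH]c3ccccc23)C1=O`, 8.33 ug/mL

Compound 3 gives the highest of the three numbers in this assay; compound 2 and compound 1 both sit lower, each by a gap beyond the scatter. Compound 1 and compound 2 are within the scatter of each other, so nothing can be read into their order.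

Compound 4, `Cc1[nH]c2ccccc2c1C1=C(Br)C(=O)C(Br)=C(c2c(-c3ccccc3)[nH]c3ccccc23)C1=O`, is not yet measured. It differs from compound 3 in one place: phenyl in place of methyl on an aromatic carbon.

Among the measured compounds shown here, only one single-point step has been measured, a 1.1-fold higher number from compound 1 to compound 2 (0.03 log units; within the scatter), and it concerns a methyl added to a phenyl, not the exchange of methyl for phenyl. It does not bear on the step to compound 4. For the measured compounds named here, compound 1 carries a phenyl at this position and compound 3 a methyl, but their cores differ as well, so their two values give no isolated step. Going by the values given here, no measured step covers the change.

The step of a 1.4-fold lower number from compound 3 to compound 4 (0.14 log units; within the scatter) is therefore an expectation without a direct precedent, and a number near compound 3 is expected. For compound 4 the estimate is 6 ug/mL, with a range from 3 ug/mL to 12 ug/mL.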

Compound 4, half-maximal inhibitory concentration: 3.02 ug/mL
For compound 4 the middle estimate is 2.0-fold (0.30 log units) above the measured one, and the stated range covers the measured number.
By their numbers in this assay, from the lowest: compounds 1, 4 and 2 (each within the scatter of the next); then compound 3.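

In this assay, among the compounds shown here, the exchange of methyl for phenyl on the aromatic carbon next to the ring nitrogen gives a 2.8-fold lower number from compound 3 to compound 4 (0.44 log units; beyond the scatter) and is the first isolated reading of this change. The step is modest but beyond the scatter, so on the core shared by compound 3 and compound 4 this position accepts the phenyl ring without any loss, and the number moves towards stronger inhibition. No measurement shown here accounts for this step.

On these data alone, whether the step comes from the aromatic ring itself stays open, as a longer chain such as propyl, a cyclohexyl ring, a pyridine ring, an amine or a carboxylic acid at this position would be needed to tell. Also open, as far as these compounds go, is whether the same exchange would move the number on the core of compound 1.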